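The compounds below may be only part of what the source reports. "The series", "measured", "known", "first", "only" and "open" are said of these compounds alone.

Measured so far in a functional assay on CCRF-CEM cells (Homo sapiens) for cytotoxicity, read by XTT assay, with a stated time of 3 days; a higher number here means a weaker inhibitor, a lower number a stronger inhibitor
- compound 1 `OC[C@H]1O[C@@H](n2cc(Cl)c3c(-c4ccccc4)ncnc32)[C@H](O)[C@@H]1O` gives 910 nM
- compound 2 `OC[C@H]1O[C@@H](n2cc(Cl)c3c(-c4cccs4)ncnc32)[C@H](O)[C@@H]1O` gives 2700 nM
- compound 3 `OC[C@H]1O[C@@H](n2cc(Cl)c3c(-c4ccoc4)ncnc32)[C@H](O)[C@@H]1O` gives 1100 nM

Compound 3 stays within the scatter of compound 1 (a 1.2-fold higher number from compound 1 to compound 3 (0.08 log units; within the scatter)) and stands apart from compound 2 (a 2.5-fold lower number from compound 2 to compound 3 (0.39 log units; beyond the scatter)).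

The open case is compound 4 `OC[C@H]1O[C@@H](n2cc(Cl)c3c(-c4ccsc4)ncnc32)[C@H](O)[C@@H]1O`, which differs from compound 3 by one group (thiophen-3-yl in place of furan-3-yl on an aromatic carbon): thiophen-3-yl in place of furan-3-yl on an aromatic carbon. Within the data shown here, no measured step makes this swap on its own. Among the measured compounds shown here, the closest evidence is compound 2, the only measured compound with a thiophene ring. Its thiophen-2-yl gave a modest change from the phenyl of compound 1 (a 3.0-fold higher number from compound 1 to compound 2 (0.47 log units; beyond the scatter)), whereas furan-3-yl in the same comparison stayed within the scatter (a 1.2-fold higher number from compound 1 to compound 3 (0.08 log units; within the scatter)). That link between a thiophene ring and a higher number rests on compound 2 alone, and its thiophen-2-yl is not the group entering here. A small move towards a higher number in this assay is therefore expected, probably not beyond the scatter. The expected step is small (a 1.4-fold higher number from compound 3 to compound 4 (0.13 log units; within the scatter)). Compound 4 is estimated at 1500 nM (expected range 700 nM to 3300 nM).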

Compound 4, half-maximal inhibitory concentration: 1000 nM
For compound 4 the middle estimate is 1.5-fold (0.18 log units) above the measured one; the range from low to high includes it.
By their numbers in this assay, from the lowest: compounds 1, 4 and 3 (each within the scatter of the next); then compound 2.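

In this assay, thiophen-3-yl in place of furan-3-yl on this aromatic carbon stays within the scatter (a 1.1-fold lower number from compound 3 to compound 4 (0.04 log units; within the scatter)), and so does thiophen-3-yl in place of phenyl (a 1.1-fold higher number from compound 1 to compound 4 (0.04 log units; within the scatter)), so a thiophene ring at this position does not in itself go with a higher number. Changing only the point of attachment, thiophen-3-yl in place of thiophen-2-yl, gives a step beyond the scatter (a 2.7-fold lower number from compound 2 to compound 4 (0.43 log units; beyond the scatter)), which ties the earlier rise to thiophen-2-yl among these groups, with phenyl, furan-3-yl and thiophen-3-yl indistinguishable from one another and thiophen-2-yl the only exception. No independent data bear on why the two thiophene attachments differ in this cell assay.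

Among these compounds, open is whether furan-2-yl would follow thiophen-2-yl towards a higher number, which would show whether this step extends beyond the single thiophene pair. Also open, on these data alone, is whether the range seen with aromatic rings holds for a non-aromatic group on this carbon, such as an amine or a longer alkyl chain.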